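The compounds below may be only part of what the source reports. "The series", "measured", "known", "first", "only" and "open" are said of these compounds alone.

Measured so far in a functional assay on L5178Y cells (Mus musculus) for inhibition, read by MTT assay, with a stated time of 24 h; on this read-out higher numbers stand for weaker inhibition and lower numbers for stronger inhibition:

Compound 1 `O=C(Cc1c[nH]c2ccccc12)N/N=C1\C[C@@H](c2ccc(O)cc2)Oc2cc(O)cc(O)c21` gives >= 11300 nM, a limit of the assay rather than a number.
Compound 2 `O=C(N/N=C1\C[C@@H](c2ccc(O)cc2)Oc2cc(O)cc(O)c21)OCc1ccccc1` gives >= 11300 nM, again a limit.
Compound 3 `COc1cc(O)c2c(c1)O[C@H](c1ccc(O)cc1)C/C2=N\NC(=O)Cc1c[nH]c2ccccc12` gives >= 11300 nM, again a limit.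

Compound 1 and compound 2 differ by benzyloxy in place of (1H-indol-3-yl)methyl on a carbonyl carbon. The step across this pair reads a step that the two limits leave unreadable from compound 1 to compound 2. The core of compound 3 differs from the core of compound 1 by methyl in place of hydrogen on an oxygen on an aromatic ring, and that step reads a step that the two limits leave unreadable from compound 1 to compound 3. Nothing among the three can be ordered, because every value shown sits at the limit of >= 11300 nM in this assay, at which 3 of the 3 values shown sit; the measured series carries no readable step at all.

Compound 4 `COc1cc(O)c2c(c1)O[C@H](c1ccc(O)cc1)C/C2=N\NC(=O)OCc1ccccc1` has not been measured. It differs from compound 3 by benzyloxy in place of (1H-indol-3-yl)methyl on a carbonyl carbon, the same change as from compound 1 to compound 2, at the same place on the carbonyl carbon, set this time on the core that carries methoxy in place of hydroxy. In this assay the expected step is a step that the limit leaves unreadable from compound 3 to compound 4, and this expectation rests only on compound 1 and compound 2 both resting at the limit of >= 11300 nM in this assay, at which 3 of the 3 values shown sit, so that the change carried neither partner off the limit. Compound 3 likewise sits at the limit, and compound 4 is therefore expected to return the limit too. The estimate for compound 4 is 15000 nM, with an expected range from 8000 nM to 60000 nM.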

Compound 4, half-maximal inhibitory concentration: >= 11300 nM
Compound 4: a limit, no number (the forecaster's own chance of this, stated with the estimate: 85%); the middle value is on the limit's open side.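

In this assay compound 4 also returns a limit, so no new step can be read from compound 3 or compound 2 to compound 4, because all the values sit at one limit: the limit of >= 11300 nM in this assay, at which 4 of the 4 values shown sit.

The compounds shown leave open what size of effect, if any, benzyloxy in place of (1H-indol-3-yl)methyl or methyl in place of hydrogen on an oxygen on an aromatic ring has on inhibition.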